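Compound 3 to compound 4: one aromatic group exchanged

The source may hold more compounds than are shown below. What is called first, only, known or untested is meant among the compounds shown, and "the series" means these compounds.

In an in vitro ADME assay on microsomes from liver (Homo sapiens) for metabolic stability (a lower number here means slower removal, a higher number faster removal of the compound), compound 3 (`CC[C@H](C)[C@@H]1C(=O)N[C@H](C2Cc3ccccc3C2)C(=O)N1[C@@H](C(=O)N(C)C)c1ccc(C)nc1C`) stands second highest of the three measured compounds at 7 mL.min-1.g-1 in this series. Compound 1 (`CC[C@H](C)[C@@H]1C(=O)N[C@H](C2Cc3ccccc3C2)C(=O)N1[C@@H](C(=O)N1CCOCC1)c1cnc(C)cc1C`) lies lower at 1 mL.min-1.g-1 with a gap to compound 3 that is beyond the scatter. Compound 2 (`Cc1ccc([C@H](C(=O)N(C)C)N2C(=O)[C@@H](C3Cc4ccccc4C3)NC(=O)[C@H]2CC(C)C)cn1`) lies far higher at 11000 mL.min-1.g-1 and is also beyond the scatter. For the measured compounds named here, no two measured compounds differ in one place, so no single-change step is available as a guide.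

Going by the values given here, compound 4 (`CC[C@H](C)[C@@H]1C(=O)N[C@H](C2Cc3ccccc3C2)C(=O)N1[C@@H](C(=O)N(C)C)c1ccc(C)[n+]([O-])c1`) carries a group of 8 heavy atoms (6 carbon, 1 nitrogen, 1 oxygen; one six-membered aromatic ring with 1 hetero atom) in place of a group of 8 heavy atoms (7 carbon, 1 nitrogen; one six-membered aromatic ring with 1 hetero atom), on a saturated chain carbon bound to an amide-type nitrogen in a ring and a carbonyl carbon as its one change from compound 3, and the group that leaves is 2,6-dimethylpyridin-3-yl.

The expected step is a modest fall, a 2.3-fold lower number from compound 3 to compound 4 (0.37 log units; beyond the scatter) as estimated here. The starting point is compound 3 at 7 mL.min-1.g-1 and compound 1 at 1 mL.min-1.g-1 shows that lower values occur in the series. Compound 2 at 11000 mL.min-1.g-1 shows how wide the spread can be, so the upper end is kept generous. Compound 4 is estimated at 3 mL.min-1.g-1 with an expected range from 1 mL.min-1.g-1 to 15 mL.min-1.g-1 as its bounds.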

Compound 4, intrinsic clearance in microsomes: 1 mL.min-1.g-1
The estimate for compound 4 lay 3.0-fold (0.48 log units) above the measured number, within the range that was stated.
By their numbers in this assay, from the lowest: compounds 1 and 4 (each within the scatter of the next); then compound 3; then compound 2.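

In this assay, the exchange of 2,6-dimethylpyridin-3-yl for the aromatic group containing oxygen, on a saturated chain carbon bound to an amide-type nitrogen in a ring and a carbonyl carbon, gives a 7.0-fold lower number from compound 3 to compound 4 (0.85 log units; beyond the scatter). For the compounds shown here, this is the first single-change step available, and it shows that the number responds to the aromatic group at this position while the rest of compound 3 stays the same, even though the two groups have the same counted hydrogen-bond donors, hydrogen-bond acceptors and net charge. No measurement shown here accounts for the step.

This single pair leaves open how far the step depends on the added oxygen and how far on the other difference between the two groups. Also open, as far as these compounds go, is how the number would move with a phenyl ring carrying an amine or a carboxylic acid at this position.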